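Carboxy to carbamoyl on the shared core

The source may report more compounds than this note shows. Statements on the series, on what has been measured and on what is new or still open speak of the compounds shown alone.

Two compounds have been measured in a physicochemical assay for solubility, in phosphate buffer, at pH 6.5; on this read-out higher numbers stand for higher solubility and lower numbers for lower solubility:

Compound 1 `C=C[C@@H]1C[C@]1(NC(=O)[C@@H]1C[C@@H](Oc2nccc3cc(OC)ccc23)CN1C(=O)[C@@H](NC(=O)N[C@@H](CC)COC)C(C)(C)C)C(=O)NS(=O)(=O)C1CC1`: 500 ug/mL
Compound 2 `C=C[C@@H]1C[C@]1(NC(=O)[C@@H]1C[C@@H](Oc2nccc3cc(OC)ccc23)CN1C(=O)[C@@H](NC(=O)N[C@H](C(=O)O)C(C)(C)C)C(C)(C)C)C(=O)NS(=O)(=O)C1CC1`: > 1160 ug/mL (a limit of the assay)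

Compound 2 stands at the upper end of these two results, and its > 1160 ug/mL is a limit, not a number. Compound 3 `C=C[C@@H]1C[C@]1(NC(=O)[C@@H]1C[C@@H](Oc2nccc3cc(OC)ccc23)CN1C(=O)[C@@H](NC(=O)N[C@H](C(N)=O)C(C)(C)C)C(C)(C)C)C(=O)NS(=O)(=O)C1CC1` differs from compound 2 in one place: amino in place of hydroxy on a carbonyl carbon. Carboxy thus becomes carbamoyl. Within the data shown here, the one measured step bearing on this is an at least 2.3-fold higher number from compound 1 to compound 2 (0.36 log units; beyond the scatter), which put 1-carboxy-2,2-dimethylpropyl in place of 1-(methoxymethyl)propyl. With that carboxy gone from compound 3, a fall of similar size is expected, back towards compound 1 at 500 ug/mL. The expected change is an at least 2.9-fold lower number from compound 2 to compound 3 (0.46 log units; beyond the scatter). For compound 3 the estimated value in this assay is 400 ug/mL, with an expected range of 100 ug/mL to 1200 ug/mL.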

Compound 3, solubility: 557 ug/mL
For compound 3 the middle estimate is 1.4-fold (0.14 log units) below the measured one; the range from low to high includes it.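

In this assay, carboxy to carbamoyl on the carbonyl carbon gives an at least 2.0-fold lower number from compound 2 to compound 3 (0.31 log units; beyond the scatter), so the hydroxy on that carbon matters to this read-out even though the swap exchanges one heavy atom for one other. Among these compounds, compound 2 sits at a limit of the assay, so this step has a lower bound only: the limit of > 1160 ug/mL in this assay, at which 1 of the 3 values shown sits. The 1-carbamoyl-2,2-dimethylpropyl group in place of 1-(methoxymethyl)propyl gives a 1.1-fold higher number from compound 1 to compound 3 (0.05 log units; within the scatter), which leaves the carboxy of compound 2 as the only one of these groups set apart from the others on this read-out.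

As far as these compounds go, how far compound 2 truly lies from the other two remains open. From the compounds shown here alone, it is also open whether a methyl ester, a methylamide or a tetrazole on the same carbon would side with the carboxy or with the carbamoyl.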